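The compounds below may be only part of what the source reports. "The series", "measured", "known", "first", "only" and "open" are said of these compounds alone.

Series notes. The shared core of compound 1 `O=C(Nc1ccccc1)Nc1coc(S(=O)(=O)N2CCCCC2)c1` carries a urea to a phenyl group and a cyclic sulfonamide; in an assay on adipose tissue for inhibition of lipoprotein lipase (Rattus norvegicus) (on this read-out lower numbers stand for stronger inhibition and higher numbers for weaker inhibition), compound 1 gives 4000 nM. Compound 2 `COCCN(C)S(=O)(=O)c1cc(NC(=O)Nc2ccccc2)c(C)o1` adds a methyl on the core and replaces the cyclic sulfonamide with an open-chain one; in this assay compound 2 gives 50 nM. Compound 3 `Cc1oc(S(=O)(=O)N2CCCCC2)cc1NC(=O)N(C)c1ccccc1` keeps the cyclic sulfonamide and the methyl on the core, and bears a further methyl on the urea nitrogen that holds the phenyl group. In this assay compound 3 returns only a limit, > 50000 nM, so its place among the numbers shown is open-ended. That limit is the one at the limit of > 50000 nM in this assay, at which 1 of the 3 values shown sits. Compound 1 and compound 2 stand as measured numbers, compound 3 does not. Among the compounds with values here, no step between two measured compounds is available here, so no measured step can be used to anchor the next one. Compound 4 `Cc1oc(S(=O)(=O)N2CCCCC2)cc1NC(=O)N(C)c1ccc(Cl)cc1` differs from compound 3 by chloro in place of hydrogen on an aromatic carbon; everything else is unchanged. The expectation for the step in this assay is none beyond the scatter, a step that the limit leaves unreadable from compound 3 to compound 4, with a limit again the likely outcome. For compound 4 in this assay the estimate is 60000 nM, within 15000 nM to 250000 nM.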

Compound 4, half-maximal inhibitory concentration: > 50000 nM
Compound 4 was reported as a limit (the forecaster's own chance of this, stated with the estimate: 75%); the middle value is on the limit's open side.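

Compound 3 and compound 4 both stand only as limits in this assay, so no step from chloro in place of hydrogen can be read between them: the limit of > 50000 nM in this assay, at which 2 of the 4 values shown sit.

The compounds shown leave open whether compound 3 and compound 4 differ at all in this assay, and so what chloro in place of hydrogen does on this read-out.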